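A few compounds are considered here, and "the series" means these few. Any claim that something is new, unique, unknown or untested is made for them only; others in the source may bear on it.

Measured so far in a functional assay on the whole organism for antagonist activity, with Rattus norvegicus as the target; a lower number here means that less compound is needed, a higher number that more compound is needed for the effect:
- compound 1 `O=C(Nc1ccc(C(=O)N2CCCN(CCN3CCCC3)c3sccc32)cc1)c1ccccc1-c1ccccc1`: > 0.3 mg/kg
- compound 2 `CN1CCN(C(=O)CCCOc2cc(C(=O)N3CCCCc4sccc43)ccc2NC(=O)c2ccccc2-c2ccccc2)CC1`: 0.03 mg/kg
- compound 3 `O=C(Nc1ccc(C(=O)N2CCCCc3sccc32)cc1OCCCC(=O)N1CCC(N2CCCCC2)CC1)c1ccccc1-c1ccccc1`: 0.03 mg/kg

Compound 1 is reported only as a limit, > 0.3 mg/kg.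

Compound 3 stands level with compound 2 at 0.03 mg/kg. The next change leads to compound 4 `CN1CCCN(CCCOc2cc(C(=O)N3CCCCc4sccc43)ccc2NC(=O)c2ccccc2-c2ccccc2)CC1`: 4-methyl-1,4-diazepan-1-yl in place of (4-methylpiperazin-1-yl)carbonyl on a saturated chain carbon, three bonds along the chain from an oxygen on an aromatic ring. It can also be read as 3-(4-methyl-1,4-diazepan-1-yl)propyl replacing 3-((4-methylpiperazin-1-yl)carbonyl)propyl.

Among the measured compounds shown here, one measured step bears on this change: no change at the digits printed from compound 2 to compound 3 (within the scatter), with 4-(piperidin-1-yl)piperidin-1-yl in place of 4-methylpiperazin-1-yl on a carbonyl carbon. For the measured compounds named here, that step keeps the carbonyl, whereas the new change removes it, and no measured step covers such a removal. The support is therefore indirect, and the range is kept wide.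

No shift beyond the scatter is expected in this assay, in either direction, and the estimated step is a 1.3-fold higher number from compound 2 to compound 4 (0.12 log units; within the scatter). The expected value for compound 4 is 0.04 mg/kg. The estimated range for compound 4 runs from 0.012 mg/kg to 0.15 mg/kg.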

Compound 4, dose for 50% inhibition: 0.03 mg/kg
Estimate against measurement, compound 4: 1.3-fold (0.12 log units) above, and the stated range covers the measured number.
By their numbers in this assay, from the lowest: compounds 2, 3 and 4 (each within the scatter of the next). At a limit, above all of these: compound 1.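

In this assay, putting 4-methyl-1,4-diazepan-1-yl in place of (4-methylpiperazin-1-yl)carbonyl on the saturated chain carbon gives no change at the digits printed from compound 2 to compound 4 (within the scatter). Among the compounds shown here, compounds 2 and 3 both carry the carbonyl, so only this pair shows that the dose needed can hold without it, and with a seven-membered ring in place of a six-membered one at the chain end. None of the data shown gives a reason for this result.

The step alters the carbonyl and the ring together, so a 3-(4-methylpiperazin-1-yl)propyl chain with no carbonyl would be needed to separate the two. From the compounds shown here alone, whether a ring amine is needed at this position at all remains open, and a chain ending in a hydroxyl group or a carboxylic acid would address that.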